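Ester chain lengthening at the limit of the cytotoxicity read-out

The compounds below may be only part of what the source reports. "The series", "measured", "known", "first", "only" and "open" are said of these compounds alone.

Measured in a functional assay on PBM cells (Homo sapiens) for cytotoxicity (on this read-out lower numbers stand for stronger inhibition and higher numbers for weaker inhibition), so far:
- compound 1 `O=C1NC(O)C(F)=CN1[C@H]1C=C[C@@H](CO)O1` gives 32200 nM
- compound 2 `CC(=O)OC[C@@H]1C=C[C@H](n2cc(F)c(N)nc2=O)O1` gives > 100000 nM as a limit

Compound 2 has no number of its own in this assay and stands at the limit of the assay, as the limit of > 100000 nM in this assay, at which 1 of the 2 values shown sits, shows. Compound 3 `CCCC(=O)OC[C@@H]1C=C[C@H](n2cc(F)c(N)nc2=O)O1` differs from it by ethyl in place of hydrogen on a saturated chain carbon bound to a carbonyl carbon, which is ethyl in place of hydrogen on a saturated chain carbon bound to a carbonyl carbon, or acetoxy to (propylcarbonyl)oxy. Going by the values given here, no measured step covers this change, so only a small move towards stronger inhibition, or none beyond the scatter, is expected. The expected step is an at least 1.4-fold lower number from compound 2 to compound 3 (0.15 log units; that floor lies within the scatter), counted from a limit. For compound 3 the estimated value is 70000 nM, with an expected range of 25000 nM to 100000 nM in this assay.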

Compound 3, half-maximal inhibitory concentration: > 100000 nM
Compound 3: a limit, no number (the forecaster's own chance of this, stated with the estimate: 55%); middle value at least 1.4-fold (0.15 log units) from the limit.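

No step can be read from compound 2 to compound 3, because both stand at a limit and neither has a number: the limit of > 100000 nM in this assay, at which 2 of the 3 values shown sit.

Left open is whether acetoxy to (propylcarbonyl)oxy shifts the value in this assay at all.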